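Extending the Disulfide Chain from Hexyl to Octyl

A few compounds are considered here, and "the series" means these few. Any claim that something is new, unique, unknown or untested is made for them only; others in the source may bear on it.

Compound 3 `CCCCCCSS[C@H]1C[C@H](n2cc(C)c(=O)[nH]c2=O)O[C@@H]1CO` carries a hexyl group on a sulfur of a disulfide attached to the shared core. In a physicochemical assay for pharmacokinetics, at pH 7.2 (on this read-out higher numbers stand for a longer-lived compound and lower numbers for a shorter-lived compound), compound 3 gives < 0.0834 h, which is a limit of the assay and not a number. Compound 1 `Cc1cn([C@H]2C[C@H](SSc3ccccc3[N+](=O)[O-])[C@@H](CO)O2)c(=O)[nH]c1=O` has a 2-nitrophenyl in that place, and in this assay compound 1 gives < 0.0834 h, also a limit. Compound 2 `Cc1cn([C@H]2C[C@H](SSc3ccc([N+](=O)[O-])cc3)[C@@H](CO)O2)c(=O)[nH]c1=O` has a 4-nitrophenyl there, and in this assay compound 2 gives < 0.0834 h, again a limit. Because (the limit of < 0.0834 h in this assay, at which 3 of the 3 values shown sit), none of the steps a step that the two limits leave unreadable from compound 1 to compound 3, a step that the two limits leave unreadable from compound 2 to compound 3 or a step that the two limits leave unreadable from compound 1 to compound 2 can be sized. Compound 4 `CCCCCCCCSS[C@H]1C[C@H](n2cc(C)c(=O)[nH]c2=O)O[C@@H]1CO` differs from compound 3 by ethyl in place of hydrogen on a saturated chain carbon, six bonds along the chain from a sulfur. For the measured compounds named here, no measured step mirrors this change, so the measured compounds give no direction for it. Compound 4 is expected to sit at 0.05 h, between 0.015 h and 0.15 h, most likely reported once more as a limit. The step that the limit leaves unreadable from compound 3 to compound 4 is accordingly expected to be small.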

Compound 4, half-life: < 0.0834 h
Compound 4: no number, only a limit; the forecaster's own chance of this, stated with the estimate: 80%; the middle value lies beyond the limit too.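

Compound 4 ends at a limit, as do compound 1, compound 2 and compound 3, so no step among them can be read in this assay: the limit of < 0.0834 h in this assay, at which 4 of the 4 values shown sit.

Whether octyl in place of hexyl changes the half-life at all remains open, as does the actual half-life of each of these compounds.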